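Isoquinoline carboxamide esters: serine analogue to aspartate analogue

A few compounds are considered here, and "the series" means these few. Any claim that something is new, unique, unknown or untested is made for them only; others in the source may bear on it.

Measured so far:
compound 1, `O=C(N[C@@H](CO)C(=O)OCc1ccccc1)c1cc2ccccc2cn1`: 70.4 nM
compound 2, `O=C(C[C@@H]1CCCN1C(=O)c1cc2ccccc2cn1)OCc1ccccc1`: 53.4 nM

Both compounds carry the same aryl amide core joined to a benzyl ester. In a functional assay on HL-60 cells (Homo sapiens) for antiproliferative activity, read by MTT assay, with a stated time of 48 h (on this read-out lower numbers stand for stronger inhibition and higher numbers for weaker inhibition), compound 1 gives 70.4 nM, the highest of the two numbers; in this assay compound 2 gives 53.4 nM, and the gap between the two lies within the scatter, so no order between them can be read.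

The next compound, compound 3, `O=C(C[C@H](NC(=O)c1cc2ccccc2cn1)C(=O)OCc1ccccc1)OCc1ccccc1`, follows from compound 1 by one change: benzyloxycarbonyl in place of hydroxy on a saturated chain carbon, two bonds along the chain from an amide-type nitrogen and a carbonyl carbon. Among the measured compounds shown here, no pair of measured compounds shows a step of this kind, so nothing tells how it will turn out. Given that compound 1 and compound 2, which differ in this same chain region, sit within the scatter of each other, a small step is expected for compound 3, with a 1.2-fold lower number from compound 1 to compound 3 (0.07 log units; within the scatter), in no particular direction beyond the scatter. Compound 3 is accordingly expected at 60 nM, with a range from 20 nM to 180 nM.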

Compound 3, half-maximal inhibitory concentration: 74 nM
The estimate for compound 3 lay 1.2-fold (0.09 log units) below the measured number; the measured number falls inside the stated range.
By their numbers in this assay, from the lowest: compounds 2, 1 and 3 (each within the scatter of the next).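

In this assay, benzyloxycarbonyl in place of hydroxy on a saturated chain carbon, two bonds along the chain from an amide-type nitrogen and a carbonyl carbon, gives a 1.1-fold higher number from compound 1 to compound 3 (0.02 log units; within the scatter) and so no readable change. This position therefore accepts a much larger group, with a six-membered aromatic ring and no hydrogen-bond donor, without leaving the scatter of the hydroxy compound. Nothing available explains why the two groups read alike.

Going by these compounds, whether this holds for other groups at the position remains open, for example an amine, a carboxylic acid or a longer chain carrying the same ester. The compounds shown also do not tell whether the result depends on the benzyl ester that compound 1 and compound 3 share.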